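A few compounds are considered here, and "the series" means these few. Any claim that something is new, unique, unknown or untested is made for them only; others in the source may bear on it.

Compound 1 `COc1ccc(C(=O)c2cc(OC)c(OC)c(OC)c2)cc1N` — 30 nM
Compound 2 `COc1cccc(/C=C/C(=O)Nc2cc(C(=O)c3cc(OC)c(OC)c(OC)c3)cc(OC)c2OC)c1` — 6700 nM
Compound 3 `COc1cc(C(=O)c2cc(OC)c(OC)c(OC)c2)cc(NC(=O)/C=C/c2ccc(C(F)(F)F)cc2)c1OC` — 3300 nM

In a functional assay on B16 cells (Mus musculus) for cytotoxicity, read by MTT assay, with a stated time of 72 h (a lower number here means a stronger inhibitor, a higher number a weaker inhibitor), compound 2 gives the highest number of the three measured; compound 3, its nearest neighbour, lies a 2.0-fold lower number from compound 2 to compound 3 (0.31 log units; beyond the scatter) away, while compound 1, with its free amine, is far lower. Compound 4 `COc1cc(C(=O)c2cc(OC)c(OC)c(OC)c2)cc(N)c1OC` differs from compound 2 by hydrogen in place of (2-(3-methoxyphenyl)ethenyl)carbonyl on a nitrogen on an aromatic ring. Among the measured compounds shown here, no measured step matches this change directly: the only step recorded, from compound 2 to compound 3, swaps one aryl group for another and is modest. What bears most on it is the contrast between compound 2 and compound 1, whose values show that a compound with an unsubstituted amine on this core can reach a far lower number. Compound 4 is therefore expected to fall strongly, by about a 45-fold lower number from compound 2 to compound 4 (1.65 log units; beyond the scatter), to roughly 150 nM (range 20 nM to 1500 nM).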

Compound 4, half-maximal inhibitory concentration: 12500 nM
For compound 4 the middle estimate is 83-fold (1.92 log units) below the measured one; the measured number lies above the stated range.
By their numbers in this assay, from the lowest: compound 1; then compound 3; then compounds 2 and 4 (each within the scatter of the next).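

Hydrogen in place of (2-(3-methoxyphenyl)ethenyl)carbonyl on the nitrogen gives a 1.9-fold higher number from compound 2 to compound 4 (0.27 log units; within the scatter), so in this assay a free amine on the nitrogen does not by itself bring the low number of compound 1. The two amines differ by methoxy in place of hydrogen on an aromatic carbon, and a 420-fold higher number from compound 1 to compound 4 (2.62 log units; beyond the scatter) shows that this one place carries the large step among these compounds. Nothing measured here gives a reason for either step.

From the compounds shown here alone, whether an ethoxy group or a chlorine atom on that aromatic carbon would lie nearer compound 1 or compound 4 stays open. So does the effect of the (2-(3-methoxyphenyl)ethenyl)carbonyl on the nitrogen of compound 1.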